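The source may hold more compounds than are shown below. What is called first, only, known or untested is meant among the compounds shown, and "the series" means these compounds.

Measured so far:
Compound 1 `COc1ccc(-c2nc(SC)n(C)c(=O)c2C#N)cc1` gives 53 ug/mL in a functional assay on microsomes for inhibition, with a stated time of 1 h; on this read-out higher numbers stand for weaker inhibition and lower numbers for stronger inhibition.
Compound 2 `COc1ccc(-c2nc(NN)n(C)c(=O)c2C#N)cc1` gives 39 ug/mL in this assay.
Compound 3 `COc1cccc(-c2nc(NN)n(C)c(=O)c2C#N)c1OC` gives 37 ug/mL in this assay.

Compound 4 `COc1cccc(-c2nc(SC)n(C)c(=O)c2C#N)c1OC` has not yet been measured. Compound 1 differs from compound 2 by methylsulfanyl in place of aminoamino on an aromatic carbon, and that change made a step of a 1.4-fold higher number from compound 2 to compound 1 (0.13 log units; within the scatter). The difference between the core of compound 3 and that of compound 2 is not broken down here. Compound 4 differs from compound 3 by methylsulfanyl in place of aminoamino on an aromatic carbon, the same kind of change; around the place, compound 2 carries a group of 8 heavy atoms where compound 3 carries a large group. On the strength of the earlier step of a 1.4-fold higher number from compound 2 to compound 1 (0.13 log units; within the scatter), which lay within the scatter, the expected change in this assay is a 1.4-fold higher number from compound 3 to compound 4 (0.13 log units; within the scatter). Compound 4 is accordingly estimated at 50 ug/mL, with a likely range from 28 ug/mL to 90 ug/mL.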

Compound 4, half-maximal inhibitory concentration: 48 ug/mL
Compound 4: the middle estimate sits 1.0-fold (0.02 log units) above what was measured; the range from low to high includes it.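

In this assay, methylsulfanyl in place of aminoamino gave a 1.3-fold higher number from compound 3 to compound 4 (0.11 log units; within the scatter), and the step carried over from one core to the other with no difference beyond the scatter: the same change on two cores in this assay, a 1.4-fold higher number (0.13 log units; within the scatter) from compound 2 to compound 1 and a 1.3-fold higher number (0.11 log units; within the scatter) from compound 3 to compound 4, 1.0-fold (0.02 log units) apart, within the scatter of two such steps. This shows that the swap behaved alike on these two cores, but since both steps lie within the scatter, the agreement is one between two small steps and does not establish a real effect of the swap. It also does not show how the change would behave on any other core, or where a step beyond the scatter occurred.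

The compounds shown leave open what a simple amine, a carboxylic acid or a longer sulfur-linked chain would give on this aromatic carbon between two ring nitrogen atoms in this assay. They also leave open whether any such group would give a step beyond the scatter.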